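Swapping a tert-butyl for pyrrolidinyl on the outer ring

The compounds below may be only part of what the source reports. "The series", "measured", "known", "first", "only" and "open" are said of these compounds alone.

Of the compounds shown here, two sharing one core have been measured in an in vitro functional assay on cells for antagonist activity at transient receptor potential cation channel subfamily V member 1 (Homo sapiens), read by FLIPR and calcium flux; on this read-out higher numbers stand for weaker inhibition and lower numbers for stronger inhibition. Compound 1 `O=C1CCc2cccc(Nc3ncc(-c4ccc(C(F)(F)F)cc4)o3)c2C1` gives 374 nM. Compound 2 `CC(C)(C)c1ccc(-c2cnc(Nc3cccc4c3CC(O)CC4)o2)cc1`, which carries a tert-butyl group on the outer ring and a hydroxyl on the core, gives 26 nM, the lowest of the two numbers and a step beyond the usual scatter away from compound 1. Among the measured compounds shown here, compound 3 `OC1CCc2cccc(Nc3ncc(-c4ccc(N5CCCC5)cc4)o3)c2C1` keeps the hydroxyl core of compound 2 and changes only one group: pyrrolidin-1-yl in place of tert-butyl on an aromatic carbon. For the measured compounds named here, no measured pair shows this particular exchange, so the expectation rests on the standing of compound 2 alone. The step from compound 2 to compound 3 is expected to be small, most likely none beyond the scatter, with a slight lean toward weaker inhibition, as a 1.9-fold higher number from compound 2 to compound 3 (0.28 log units; within the scatter) expresses. Compound 3 is therefore estimated at 50 nM, within a range from 12 nM to 200 nM in this assay.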

Compound 3, half-maximal inhibitory concentration: 101 nM
For compound 3 the middle estimate is 2.0-fold (0.31 log units) below the measured one; the measured number falls inside the stated range.
By their numbers in this assay, from the lowest: compound 2; then compound 3; then compound 1.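

In this assay, placing pyrrolidin-1-yl instead of tert-butyl on this aromatic carbon gives a 3.9-fold higher number from compound 2 to compound 3 (0.59 log units; beyond the scatter), so what sits at this position does matter, even when the rest of the molecule stays the same. The change is modest, though: with the new group and its ring nitrogen in place, compound 3 still gives 101 nM, so inhibition is weakened but not lost. No measurement offered here explains why this exchange weakens inhibition.

Since the two groups differ in both their ring and their nitrogen, this single pair cannot show which of these features goes with the step. Cyclopentyl, a ring of carbon only, and dimethylamino, a nitrogen group without a ring, would help separate the two on the same hydroxyl-bearing core.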